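Nitro on the phenyl of a piperazine-linked quinoline

The compounds below may be only part of what the source reports. "The series", "measured", "known", "first", "only" and "open" are said of these compounds alone.

Compound 1, `CSc1nc(NCCCNc2ccnc3cc(Cl)ccc23)c(C#N)c(-c2ccccc2)n1`, gives 11000 nM in an ADME assay on HeLa cells (Homo sapiens) for inhibition, read by cell counting; a higher number here means a weaker inhibitor, a lower number a stronger inhibitor.
Compound 2, `CSc1nc(-c2ccccc2)c(C#N)c(N2CCN(c3ccnc4cc(Cl)ccc34)CC2)n1`, gives > 250000 nM in this assay.

The value for compound 2 is a limit of this assay, not a number, and it stands at the top of the range covered here: the limit of > 250000 nM in this assay, at which 1 of the 2 values shown sits. Within the data shown here, of the two compounds measured, compound 2 is therefore the one without a finite value, while compound 1 sits well inside the measurable range.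

Compound 3, `CSc1nc(-c2ccc([N+](=O)[O-])cc2)c(C#N)c(N2CCN(c3ccnc4cc(Cl)ccc34)CC2)n1`, is yet to be measured. It differs from compound 2 by nitro in place of hydrogen on an aromatic carbon. Among the measured compounds shown here, no step between two measured compounds involves this change, so there is nothing here to show which way it acts. Compound 3 is expected to remain close to where compound 2 stands, so the step that the limit leaves unreadable from compound 2 to compound 3 is expected to be small and probably within the scatter. Compound 3 is estimated at 300000 nM, with a range from 60000 nM to 1500000 nM, and a limit rather than a number is the more likely outcome.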

Compound 3, half-maximal inhibitory concentration: 228000 nM
Beside the measured number, compound 3's estimate is 1.3-fold (0.12 log units) above it; measured number inside the range.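

Nitro in place of hydrogen on an aromatic carbon, para to a large group, is the only change shown at this position, and it gives an at least 1.0-fold lower number from compound 2 to compound 3 (0.04 log units; that floor lies within the scatter), so the step can be sized from one side only and nothing shows it to exceed the scatter. In this assay compound 3 gives 228000 nM as a finite number, so the 4-nitrophenyl compound can be read where the phenyl compound cannot. The value of compound 2 remains a limit: the limit of > 250000 nM in this assay, at which 1 of the 3 values shown sits.

As far as these compounds go, whether an amine or a carboxylic acid on the same aromatic carbon would also give a finite number stays open. So does whether nitro in place of hydrogen would act in the same way on compound 1, with its open chain in place of the piperazine.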